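The compounds below may be only part of what the source reports. "The series", "measured", "known", "first", "only" and "open" are said of these compounds alone.

Measured so far in a functional assay on OVCAR cells (Homo sapiens) for inhibition, read by MTT assay, with a stated time of 48 h; a lower number here means a stronger inhibitor of growth, a higher number a weaker inhibitor of growth:

- compound 1 `Nc1ccc(-c2cc(-c3ccc(C(F)(F)F)cc3)n[nH]2)cc1` gives 18600 nM
- compound 2 `COc1ccc(-c2cc(-c3ccc(C(F)(F)F)cc3)n[nH]2)cc1` gives 22800 nM
- compound 3 `Oc1ccc(-c2cc(-c3ccc(C(F)(F)F)cc3)n[nH]2)cc1` gives 9200 nM

Compound 2 stands at the high end of these three numbers, level within the scatter with its nearest neighbour: a 1.2-fold higher number from compound 1 to compound 2 (0.09 log units; within the scatter). Its gap to the lowest number is a 2.5-fold lower number from compound 2 to compound 3 (0.39 log units; beyond the scatter).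

Still to be measured is compound 4 `COc1ccc(-c2cc(-c3ccc(Cl)cc3)n[nH]2)cc1`, which differs from compound 2 in one place: chloro in place of trifluoromethyl on an aromatic carbon. This is chloro in place of trifluoromethyl on an aromatic carbon, para to a large group.

Among the compounds with values here, no measured step touches that place. All three steps exchange amino, methoxy or hydroxy, and the trifluoromethyl stays throughout. They can therefore serve only as a rough gauge of step size in this small set. Two are modest, a 2.0-fold lower number from compound 1 to compound 3 (0.31 log units; beyond the scatter) and a 2.5-fold lower number from compound 2 to compound 3 (0.39 log units; beyond the scatter), and one, a 1.2-fold higher number from compound 1 to compound 2 (0.09 log units; within the scatter), lies within the scatter. They give no direction for the new change, so no step beyond the scatter is expected.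

The expected step is a 1.1-fold lower number from compound 2 to compound 4 (0.06 log units; within the scatter). For compound 4 the estimate is 20000 nM, with an expected range of 9000 nM to 45000 nM.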

Compound 4, concentration for 50% growth inhibition: 12800 nM
The estimate for compound 4 lay 1.6-fold (0.19 log units) above the measured number; low and high end bracket the measured number.
By their numbers in this assay, from the lowest: compounds 3, 4, 1 and 2 (each within the scatter of the next, the first and the last beyond it).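

In this assay, within the data shown here, the change to chloro in place of trifluoromethyl is the first one at this place, on an aromatic carbon para to a large group, and it gives a 1.8-fold lower number from compound 2 to compound 4 (0.25 log units; within the scatter). The earlier steps shown here all kept trifluoromethyl and exchanged only amino, methoxy or hydroxy, so they could say nothing about this position; here a group of 4 heavy atoms gives way to one of 1 heavy atom, and the two methoxy compounds stay level within the scatter. Read on this single pair, the position accepts the exchange without a change beyond the scatter, though no measurement at hand speaks to what lies behind this result.

The compounds shown leave open how other groups at this place would read, such as bromo, nitrile, a carboxylic acid or a longer chain like propyl. They also leave open whether chloro in place of trifluoromethyl reads the same way in the hydroxy compound 3 or the amino compound 1, as the chloro partners of those two are absent from this set.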